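Changing the Phenyl Group on a Shared Core

This account rests on a few compounds, and the source may have more. Where it says the series, first, only, none or still open, it means among the compounds named here.

compound 1 `Nc1scc(CN2CCN(c3ccc([N+](=O)[O-])cc3)CC2)c1C(=O)c1ccc(Cl)cc1`: 2%
compound 2 `Nc1scc(CN2CCN(c3cccc(F)c3)CC2)c1C(=O)c1ccc(Cl)cc1`: 4%
compound 3 `Nc1scc(CN2CCN(c3cccc(Cl)c3)CC2)c1C(=O)c1ccc(Cl)cc1`: 1%

In an assay on CHO cells for displacement of a labelled ligand from adenosine receptor A3 (Homo sapiens), read by scintillation counting, with a stated time of 120 min, tested at 10 uM (on this read-out lower numbers stand for less inhibition and higher numbers for more inhibition at the one concentration tested (going by the name of the read-out)), compound 1 gives 2%, the second highest of the three numbers, though the steps of a number 2 percentage points higher from compound 1 to compound 2 (within the scatter) and a number 1 percentage points lower from compound 1 to compound 3 (within the scatter) both lie within the scatter, as does a number 3 percentage points lower from compound 2 to compound 3 (within the scatter). Compound 4 `Nc1scc(CN2CCN(c3c(Cl)cccc3Cl)CC2)c1C(=O)c1ccc(Cl)cc1` differs from compound 1 by 2,6-dichlorophenyl in place of 4-nitrophenyl on an amine nitrogen in a ring. Going by the values given here, the steps that bear on this change are the two in which the 4-nitrophenyl was also exchanged for another phenyl group, a number 2 percentage points higher from compound 1 to compound 2 (within the scatter) and a number 1 percentage points lower from compound 1 to compound 3 (within the scatter); neither moved the number beyond the scatter. Among the compounds with values here, no measured step puts two chlorines on that phenyl. The expectation is therefore a step of a number 1 percentage points higher from compound 1 to compound 4 (within the scatter), nothing beyond the scatter. Compound 4 is expected to give about 3%, between 0% and 12%.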

Compound 4, a percentage reported as inhibition, at one concentration (the size of the read-out at that concentration, not a potency): 1%
Estimate against measurement, compound 4: 2 percentage points above; low and high end bracket the measured number.
By their numbers in this assay, from the lowest: compounds 3, 4, 1 and 2 (each within the scatter of the next).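

Two chlorines on the phenyl group are new at this position, yet they shift nothing beyond the scatter in this assay: there is a number 1 percentage points lower from compound 1 to compound 4 (within the scatter) and no change at the digits printed from compound 3 to compound 4 (within the scatter) and also a number 3 percentage points lower from compound 2 to compound 4 (within the scatter) here. All four phenyl groups on the ring nitrogen thus stand within the scatter of one another, with no order among them. Nothing on hand offers an explanation for this result. Going by these compounds, whether an amine or a carboxylic acid on this phenyl group, or a longer chain in its place, would move the number beyond the scatter stays open.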